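Furan-2-yl in place of 4-methoxyphenyl on the chalcone chain

The compounds below may be only part of what the source reports. "The series", "measured", "known", "first", "only" and "open" are said of these compounds alone.

Three compounds carry a measured value. Compound 1 `Nc1ccc(C(=O)/C=C/c2ccco2)cc1` is the parent with a free amine on the shared core and gives 33% in a functional assay on the whole organism (strain albino) for inhibition, with Rattus norvegicus as the target, read by paw edema, with stated times of 30 min and 1 h, at a dose of 100 mg/kg by the oral route; a higher number here means more inhibition at the dose given (going by the name of the read-out), a lower number less inhibition. Compound 2 `CC(Br)C(=O)Nc1ccc(C(=O)/C=C/c2ccc(Cl)cc2)cc1` carries the bromopropanamide and gives 39% in this assay. Compound 3 `COc1ccc(/C=C/C(=O)c2ccc(NC(=O)C(C)Br)cc2)cc1` gives 39% in this assay; this stands level with compound 2 at the digits shown, the two together being the highest of the three numbers, and the gap to compound 1 lies within the scatter. Going by the values given here, the one single-point step measured, no change at the digits printed from compound 2 to compound 3 (within the scatter), shows that exchanging the substituent on the aryl ring left the read-out unmoved.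

Compound 4 `CC(Br)C(=O)Nc1ccc(C(=O)/C=C/c2ccco2)cc1` is not yet measured. It differs from compound 3 by furan-2-yl in place of 4-methoxyphenyl on a double-bonded chain carbon bound to a double-bonded chain carbon. Among the compounds with values here, no measured step bears directly on this exchange; compound 1 carries the same furan-2-yl but also lacks the bromopropanamide, and its value against compound 3 lies within the scatter. Since the aryl exchange in no change at the digits printed from compound 2 to compound 3 (within the scatter) stayed within the scatter, the step of a number 3 percentage points lower from compound 3 to compound 4 (within the scatter) is expected to stay within the scatter as well. Compound 4 is therefore estimated at 36%, within 26% to 46%.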

Compound 4, a percentage reported as inhibition, in the whole organism at one dose (the size of the read-out at that dose, not a potency): 30%
The estimate for compound 4 lay 6 percentage points above the measured number; the range from low to high includes it.
By their numbers in this assay, from the lowest: compounds 4, 1, 2 and 3 (each within the scatter of the next).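

In this assay the furan-2-yl group on a double-bonded chain carbon bound to a double-bonded chain carbon can now be read directly against 4-methoxyphenyl, as a number 9 percentage points lower from compound 3 to compound 4 (within the scatter), and against 4-chlorophenyl, as a number 9 percentage points lower from compound 2 to compound 4 (within the scatter). Going by these compounds alone, a five-membered aromatic ring with 1 hetero atom in place of a six-membered aromatic ring of carbon only, with 5 heavy atoms entering for 8 leaving, therefore gives no step that can be told from the scatter at this position. With furan-2-yl held fixed, (1-bromoethyl)carbonyl in place of hydrogen on a nitrogen on an aromatic ring gives a number 3 percentage points lower from compound 1 to compound 4 (within the scatter), so this change likewise stays unresolved.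

No supporting measurement accounts for these readings. Going by these compounds, whether a carboxylic acid or a dimethylamino group on the aryl ring, or a longer chain on the amide carbonyl, would give a step beyond the scatter remains open.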